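Swapping the side chain on the shared core of compound 1

A few compounds are considered here, and "the series" means these few. Any claim that something is new, unique, unknown or untested is made for them only; others in the source may bear on it.

Measured compounds:
- compound 1 `Cn1ncc(Cl)c1-c1cc(C(=O)N[C@@H]2CN[C@H](CC(O)CO)C[C@H]2c2ccc(Cl)c(Cl)c2)oc1Cl`: 1110 nM
- compound 2 `Cn1ncc(Cl)c1-c1cc(C(=O)N[C@@H]2CN[C@H](CC(=O)O)C[C@H]2c2ccc(Cl)c(Cl)c2)oc1Cl`: 4020 nM
- compound 3 `CN(C)CC[C@@H]1C[C@@H](c2ccc(Cl)c(Cl)c2)[C@H](NC(=O)c2cc(-c3c(Cl)cnn3C)c(Cl)o2)CN1`: 1710 nM

In a functional assay on HCT-116 cells (Homo sapiens) for antiproliferative activity, read by sulforhodamine B assay, with a stated time of 72 h (a higher number here means a weaker inhibitor, a lower number a stronger inhibitor), compound 1 gives 1110 nM and stands with the lowest number of the three. Compound 3 sits nearest, the difference being within the scatter, so neither can be called the stronger; compound 2 is furthest, with a clear gap.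

Compound 4 `COCC[C@@H]1C[C@@H](c2ccc(Cl)c(Cl)c2)[C@H](NC(=O)c2cc(-c3c(Cl)cnn3C)c(Cl)o2)CN1` is not yet measured. It differs from compound 1 in one place: methoxymethyl in place of 1,2-dihydroxyethyl on a saturated chain carbon bound to a saturated ring carbon.

Two measured steps start from compound 1 and change the same chain. The change a 3.6-fold higher number from compound 1 to compound 2 (0.56 log units; beyond the scatter) showed that a carboxy there costs activity. The change a 1.5-fold higher number from compound 1 to compound 3 (0.19 log units; within the scatter) showed that a (dimethylamino)methyl there leaves the number essentially unchanged. Going by the values given here, the change to methoxymethyl is a third variation at the same position, with no measured counterpart, and compound 3 suggests that losing both hydroxyls need not cost much, while compound 2 warns that some groups do.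

The expectation for compound 4 is a step of a 1.4-fold higher number from compound 1 to compound 4 (0.13 log units; within the scatter), that is, little change beyond the scatter. The estimate for compound 4 in this assay is 1500 nM, within a range from 700 nM to 3500 nM.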

Compound 4, half-maximal inhibitory concentration: 470 nM
Estimate against measurement, compound 4: 3.2-fold (0.50 log units) above, and the stated range ends above it.
By their numbers in this assay, from the lowest: compound 4; then compounds 1 and 3 (each within the scatter of the next); then compound 2.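

In this assay, the change to methoxymethyl gives a 2.4-fold lower number from compound 1 to compound 4 (0.37 log units; beyond the scatter), so this position can do better than the 1,2-dihydroxyethyl chain rather than merely match it, even though the entering group has 0 hydrogen-bond donors against 2 for the group it replaces. Going by these compounds alone, the new compound also separates the chain ends from one another, with a 3.6-fold lower number from compound 3 to compound 4 (0.56 log units; beyond the scatter) and an 8.6-fold lower number from compound 2 to compound 4 (0.93 log units; beyond the scatter), so the choice of group here matters more than the earlier steps alone could show. Nothing measured here explains why the methoxymethyl chain gives the lowest number of the four.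

The step from compound 1 to compound 4 removes both hydroxyl groups and shortens the group by one heavy atom at once, so the compounds shown cannot separate the effects of those two changes. As far as these compounds go, it also remains open whether the ether oxygen matters at all: a plain ethyl group with no oxygen, or a longer ethoxymethyl group, on the same saturated chain carbon would show whether the number holds, improves or worsens.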